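A Remote Aromatic Group and Amine Acid Dissociation

The compounds below may be only part of what the source reports. "The series", "measured", "known", "first", "only" and "open" are said of these compounds alone.

In a physicochemical assay for acid dissociation, compound 2 `COc1cccc(CNCCCNc2ccnc3cc(-c4ccc(C(C)(C)C)cc4)ccc23)c1O` gives 9.47. Compound 1 `Fc1ccc(-c2ccc3c(NCCCNCc4ccco4)ccnc3c2)cc1` gives 9.47 and compound 3 `CC(C)(C)c1ccc(-c2ccc3c(NCCCNCc4ccco4)ccnc3c2)cc1` gives 9.47, so compound 2 stands level with both. Two measured steps are known: no change at the digits printed from compound 1 to compound 3 (within the scatter) and no change at the digits printed from compound 2 to compound 3 (within the scatter). Compound 4 `COc1cccc(CNCCCNc2ccnc3cc(-c4ccccc4)ccc23)c1O` differs from compound 2 by hydrogen in place of tert-butyl on an aromatic carbon. The first of these steps bears on this change, exchanging one group for another on an aromatic carbon of the same distal ring, and it stayed within the scatter. Compound 4 is therefore expected to show no step beyond the scatter, no change at the digits printed from compound 2 to compound 4 (within the scatter). The expected value for compound 4 is 9.47, with a range from 9.2 to 9.75.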

Compound 4, acid dissociation constant: 9.47
Compound 4: the middle estimate sits on the measured number at the digits printed; the range from low to high includes it.
By their numbers in this assay, from the lowest: compounds 1, 2, 3 and 4 (each within the scatter of the next).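

In this assay the tert-butyl group gives way to hydrogen, leaving a bare phenyl, with no change at the digits printed from compound 2 to compound 4 (within the scatter). The earlier step on this ring only exchanged fluoro for tert-butyl, on the furan-2-yl side chain; this one shows that the read-out also holds with no group at all on this aromatic carbon, here with the 2-hydroxy-3-methoxyphenyl side chain. No measurement shown accounts for this result. Going by these compounds, whether an amine or a carboxylic acid on this same carbon would read alike remains open, as does the effect of a longer chain there.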